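From a Tert-Butyl Ester to a Methyl Ketone

This account rests on a few compounds, and the source may have more. Where it says the series, first, only, none or still open, it means among the compounds named here.

Compound 2 `CC(C)(C)OC(=O)c1cccc(NC(=O)C2CCCN(C(=O)c3cc(C(F)(F)F)cc(C(F)(F)F)c3)C2)c1` gives 0% in an ADME assay on PC-3 cells (Homo sapiens) for cytotoxicity, read by WST assay, tested at 100 uM (on this read-out lower numbers stand for less inhibition and higher numbers for more inhibition at the one concentration tested (going by the name of the read-out)), and so sits at the low end of the three numbers. Compound 3 `O=C(Nc1ccc(Cl)cc1)C1CCCN(C(=O)c2cccc(-c3cccs3)c2)C1` gives 4% in this assay, a gap from compound 2 that is within the usual scatter, while compound 1 `O=C(Nc1ccc(Cl)cc1)C1CCCN(C(=O)c2cccc(-c3nccs3)c2)C1` gives 32% in this assay, a gap that is beyond it. Among the measured compounds shown here, the only measured step between close neighbours, a number 28 percentage points lower from compound 1 to compound 3 (beyond the scatter), concerns an exchange of one ring for another on an aromatic carbon and says nothing about the part of the molecule changed here.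

Compound 4 `CC(=O)c1cccc(NC(=O)C2CCCN(C(=O)c3cc(C(F)(F)F)cc(C(F)(F)F)c3)C2)c1` differs from compound 2 by methyl in place of tert-butoxy on a carbonyl carbon. For the measured compounds named here, no measured pair bears on this exchange on a carbonyl carbon, so there is no ground for expecting a step in either direction. The step from compound 2 to compound 4 is therefore expected to stay within the scatter, at a number 5 percentage points higher from compound 2 to compound 4 (within the scatter). For compound 4 the estimate is 5%, with a range from 0% to 20%.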

Compound 4, a percentage reported as inhibition, at one concentration (the size of the read-out at that concentration, not a potency): 0%
Compound 4: the middle estimate sits 5 percentage points above what was measured; the measured number falls inside the stated range.
By their numbers in this assay, from the lowest: compounds 2, 4 and 3 (each within the scatter of the next); then compound 1.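

Among the compounds shown here, this pair is the first measured exchange at this carbonyl carbon whose other neighbour is an aromatic carbon: in this assay, methyl in place of tert-butoxy gives no change at the digits printed from compound 2 to compound 4 (within the scatter). With the rest of the molecule held fixed, tert-butoxycarbonyl and acetyl therefore cannot be told apart in this read-out at the one concentration tested, and the tert-butoxy group is not needed to keep the number where it stands. The data shown offer no explanation for this result.

Still open, from the compounds shown here alone, is whether any group on this carbonyl carbon would move the number beyond the scatter, for instance a hydroxyl, which would make a carboxylic acid, or an amine, which would make an amide. Also open, going by these compounds, is whether the same exchange would again leave the number in place if the bis(trifluoromethyl)benzoyl part of the molecule were replaced.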